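This account rests on a few compounds, and the source may have more. Where it says the series, first, only, none or still open, it means among the compounds named here.

Measured so far in an assay on isolated protein for inhibition of cathepsin S (Homo sapiens); a higher number here means a weaker inhibitor, a lower number a stronger inhibitor:

Compound 1, `Cc1cc(-c2nn(CC(O)CN3CCC(n4c(O)nc5ccccc54)CC3)c3c2CN(S(C)(=O)=O)CC3)ccc1Cl`, gives 60 nM.
Compound 2, `CS(=O)(=O)N1CCc2c(c(-c3ccc(C(F)(F)F)cc3)nn2CC(O)CN2CCC(n3c(O)nc4ccccc43)CC2)C1`, gives 50 nM.
Compound 3, `Cn1c(=O)n(C2CCN(CC(O)Cn3nc(-c4ccc(C(F)(F)F)cc4)c4c3CCN(S(C)(=O)=O)C4)CC2)c2cc(Cl)ccc21`, gives 80 nM.

Compound 2 stands at the lowest of the three numbers, but the two changes around it leave the numbers within scatter of one another: a 1.2-fold lower number from compound 1 to compound 2 (0.08 log units; within the scatter) and a 1.6-fold higher number from compound 2 to compound 3 (0.20 log units; within the scatter). Neither change touches the linker between the two ring systems.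

Compound 4, `CS(=O)(=O)N1CCc2c(c(-c3ccc(C(F)(F)F)cc3)nn2CCCN2CCC(n3c(O)nc4ccccc43)CC2)C1`, is compound 2 with hydrogen in place of hydroxy on a saturated chain carbon bound to two saturated chain carbons. Among the measured compounds shown here, no measured step covers a change at this chain carbon; the two steps on record alter the aryl group on one side and the bicyclic group on the other, and both stayed within scatter. The expectation for compound 4 therefore rests on compound 2 with 50 nM as the only anchor, with no basis for a step beyond the scatter in either direction and a widened range to reflect the missing precedent. In this assay compound 4 is estimated at 90 nM, range 35 nM to 300 nM, which is expected to mean a 1.8-fold higher number from compound 2 to compound 4 (0.26 log units; within the scatter).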

Compound 4, half-maximal inhibitory concentration: 50 nM
Compound 4: middle estimate off by 1.8-fold (0.26 log units), on the high side; measured number inside the range.
By their numbers in this assay, from the lowest: compounds 2, 4, 1 and 3 (each within the scatter of the next).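

In this assay, among the compounds shown here, hydrogen in place of hydroxy on a saturated chain carbon bound to two saturated chain carbons gives no change at the digits printed from compound 2 to compound 4 (within the scatter), the first reading at this position, as the earlier steps lay elsewhere in the molecule. For this pair, then, the hydroxy, with its one hydrogen-bond donor and one hydrogen-bond acceptor, is not needed to keep the number at this level. Nothing on hand gives a reason for this outcome.

From the compounds shown here alone, whether an amine, a methoxy group or a fluorine on this chain carbon, or a longer chain, would keep the number in this assay stays open. Also open, going by these compounds, is whether the same removal of hydroxy would leave the number in place with the 4-chloro-3-methylphenyl group of compound 1.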